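The source may report more compounds than this note shows. Statements on the series, on what has been measured and on what is new or still open speak of the compounds shown alone.

Compound 1 `COc1ccc(NC(=O)c2nc(N)nc3ccccc23)cc1` and compound 2 `Cc1ccc(NC(=O)c2nc(N)nc3ccccc23)cc1` share one amide core and differ in a single group on an aromatic carbon. In an assay on CHO cells for displacement of a labelled ligand from adenosine receptor A3 (Homo sapiens) (a lower number here means a stronger inhibitor, a higher number a weaker inhibitor), compound 1 gives 87.5 nM and compound 2 gives 98.3 nM; compound 2 has the larger of the two numbers, but the step of a 1.1-fold higher number from compound 1 to compound 2 (0.05 log units; within the scatter) keeps both within the scatter of each other. Compound 3 `Nc1nc(C(=O)Nc2ccc(Br)cc2)c2ccccc2n1` carries bromo in place of methyl on an aromatic carbon. For the measured compounds named here, the only step at this position, a 1.1-fold higher number from compound 1 to compound 2 (0.05 log units; within the scatter), was flat, so for compound 3 no shift beyond the scatter is expected in this assay, the estimated step being a 1.1-fold lower number from compound 2 to compound 3 (0.04 log units; within the scatter). Compound 3 is estimated at 90 nM, within 35 nM to 250 nM.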

Compound 3, inhibition constant: 550 nM
The estimate for compound 3 lay 6.1-fold (0.79 log units) below the measured number; measured number outside the range, above it.
By their numbers in this assay, from the lowest: compounds 1 and 2 (each within the scatter of the next); then compound 3.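

Bromo is the first group on this aromatic carbon to move the number beyond the scatter in this assay: the step is modest whether read against methyl (a 5.6-fold higher number from compound 2 to compound 3 (0.75 log units; beyond the scatter)) or against methoxy (a 6.3-fold higher number from compound 1 to compound 3 (0.80 log units; beyond the scatter)). The flat step between methoxy and methyl therefore does not hold for every group at this position. Nothing available bears on the reason for this shift.

The compounds shown leave open whether the weaker binding is specific to bromo or extends to other halogens such as fluoro or chloro. As far as these compounds go, how an amine or a carboxylic acid at this position would read also remains open.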